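This account rests on a few compounds, and the source may have more. Where it says the series, first, only, none or still open, it means among the compounds named here.

Measured in an ADME assay on HFF cells (Homo sapiens) for cytotoxicity, with a stated time of 8 days; on this read-out higher numbers stand for lower toxicity in this test and lower numbers for higher toxicity in this test:
- compound 1 `Nc1nc(OCC(F)(F)F)c2ncn(/C=C3/CC3(CO)CO)c2n1`: > 300000 nM, a limit
- compound 2 `CCCCOc1nc(N)nc2c1ncn2/C=C1/CC1(CO)CO`: > 300000 nM, a limit

Compound 2 has only a limit in this assay, > 300000 nM. Both measured compounds sit at the limit of > 300000 nM in this assay, at which 2 of the 2 values shown sit.

Compound 3 `Nc1nc(SCc2ccccc2)c2ncn(/C=C3/CC3(CO)CO)c2n1` carries benzylsulfanyl in place of butoxy on an aromatic carbon. Within the data shown here, the only measured step, a step that the two limits leave unreadable from compound 1 to compound 2, gives no size to carry over, and it involves a different change.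

A small move towards higher toxicity in this assay is expected, with the estimated step being an at least 1.5-fold lower number from compound 2 to compound 3 (0.17 log units; that floor lies within the scatter). A further limit reading remains quite possible. The expected value for compound 3 is 200000 nM, with an estimated range of 60000 nM to 300000 nM.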

Compound 3, half-maximal cytotoxic concentration: > 300000 nM
Compound 3: no number, only a limit; the forecaster's own chance of this, stated with the estimate: 60%; middle value at least 1.5-fold (0.17 log units) away from the limit.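

In this assay compound 3 gives > 300000 nM, a limit, so no step can be read among compound 1, compound 2 and compound 3. Whether these groups differ in cytotoxicity at all stays open, as every reading is capped: the limit of > 300000 nM in this assay, at which 3 of the 3 values shown sit.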